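The source may report more compounds than this note shows. Statements on the series, on what has been measured and on what is new or still open speak of the compounds shown alone.

Compound 2 `CCCCCCCCS(=O)(=O)Nc1cc(-c2ccc(CCCC)cc2)ccc1C(=O)O` gives, in an assay on mitochondria (strain BALB/c) for inhibition of glycerol-3-phosphate acyltransferase 1, mitochondrial (Mus musculus), read by scintillation counting, with a stated time of 10 min (a lower number here means a stronger inhibitor, a higher number a weaker inhibitor), 15700 nM. Compound 1 `CCCCCCCCS(=O)(=O)Nc1cc(-c2ccc(Cl)cc2)ccc1C(=O)O` gives 18100 nM in this assay, and the two numbers lie within the scatter of each other, so neither compound stands apart from the other. Compound 3 `CCCCCCCCS(=O)(=O)Nc1cc(-c2ccc(-c3ccccc3)cc2)ccc1C(=O)O` differs from compound 2 by phenyl in place of butyl on an aromatic carbon. Among the measured compounds shown here, the only measured step at that same place, a 1.2-fold lower number from compound 1 to compound 2 (0.06 log units; within the scatter), left the number where it was, and it is the sole guide here. Compound 3 is therefore expected to show no step beyond the scatter, a 1.1-fold lower number from compound 2 to compound 3 (0.05 log units; within the scatter). The estimate for compound 3 is 14000 nM, with a range from 5000 nM to 40000 nM.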

Compound 3, half-maximal inhibitory concentration: 13500 nM
Compound 3: middle estimate off by 1.0-fold (0.02 log units), on the high side, within the range that was stated.
By their numbers in this assay, from the lowest: compounds 3, 2 and 1 (each within the scatter of the next).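

Swapping the group on this aromatic carbon, para to a large group, for a whole six-membered aromatic ring does not move the result beyond the scatter: a 1.2-fold lower number from compound 2 to compound 3 (0.07 log units; within the scatter), and a 1.3-fold lower number from compound 1 to compound 3 (0.13 log units; within the scatter). So in this assay, chloro, butyl and phenyl cannot be told apart at this place, whether the group carries a ring or not. Nothing available explains this flat result. Going by these compounds, whether an amine, a hydroxyl or a longer chain at this place would shift the number beyond the scatter remains open.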